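The source may report more compounds than this note shows. Statements on the series, on what has been measured and on what is new or still open speak of the compounds shown alone.

Measured so far:
Compound 1, `CN1CCN(c2ccc(C3=NN(C(=O)CCCl)C(c4ccc(N(C)C)cc4)C3)cc2)CC1`, gives 2.4% in a functional assay on MDA-MB-231 cells (Homo sapiens) for inhibition, read by sulforhodamine B assay, tested at 10 uM; on this read-out lower numbers stand for less inhibition and higher numbers for more inhibition at the one concentration tested (going by the name of the read-out).
Compound 2, `Cc1ccc(C(=O)N2N=C(c3ccc(N4CCN(C)CC4)cc3)CC2c2ccc(N(C)C)cc2)cc1`, gives -0.7%.
Compound 3, `CN1CCN(c2ccc(C3=NN(C(=O)c4ccc(F)cc4)C(c4ccc(N(C)C)cc4)C3)cc2)CC1`, gives 3.5%.

Compound 3 carries the highest of the three numbers, yet the steps of a number 1.1 percentage points higher from compound 1 to compound 3 (within the scatter) and a number 4.2 percentage points higher from compound 2 to compound 3 (within the scatter) both sit within the scatter, so no order among the three can be read. Compound 4, `CN1CCN(c2ccc(C3=NN(S(C)(=O)=O)C(c4ccc(N(C)C)cc4)C3)cc2)CC1`, differs from compound 3 in one place: methylsulfonyl in place of (4-fluorophenyl)carbonyl on an amine nitrogen in a ring. For the measured compounds named here, no measured step touches the group on the ring nitrogen in this way; the only steps known, a number 3.1 percentage points lower from compound 1 to compound 2 (within the scatter), a number 1.1 percentage points higher from compound 1 to compound 3 (within the scatter) and a number 4.2 percentage points higher from compound 2 to compound 3 (within the scatter), exchange one carbonyl-bearing group for another and all stay within the scatter. No step beyond the scatter is therefore expected, a number 1.5 percentage points lower from compound 3 to compound 4 (within the scatter). Compound 4 is estimated at 2%, between -8% and 12%.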

Compound 4, a percentage reported as inhibition, at one concentration (the size of the read-out at that concentration, not a potency): 0.6%
Compound 4: middle estimate off by 1.4 percentage points, on the high side; the measured number falls inside the stated range.
By their numbers in this assay, from the lowest: compounds 2, 4, 1 and 3 (each within the scatter of the next).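

Until this point the group on the amine nitrogen in the ring had only passed between carbonyl-bearing groups, whereas methylsulfonyl has no carbonyl and no ring. In this assay this exchange still gives a number 2.9 percentage points lower from compound 3 to compound 4 (within the scatter) and a number 1.3 percentage points higher from compound 2 to compound 4 (within the scatter) and a number 1.8 percentage points lower from compound 1 to compound 4 (within the scatter) at the one concentration tested. All four compounds thus remain without any readable order, and no measured evidence bears on this result.

Open, as far as these compounds go, is whether any group at this nitrogen, such as a longer chain ending in an amine or a carboxylic acid, would move the number beyond the scatter. Also open, from the compounds shown here alone, is whether a change elsewhere on the shared core would do so.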